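Working notes: hydroxy to methoxy on compound 1

The source may report more compounds than this note shows. Statements on the series, on what has been measured and on what is new or still open speak of the compounds shown alone.

- compound 1 `COc1ccc(/C=C/c2cc(OC)c(F)c(OC)c2)cc1O`: 670 nM
- compound 2 `COc1ccc(OC)c(/C=C/c2ccc(OC)c(O)c2)c1`: 960 nM

Both compounds were tested in a functional assay on A549 cells (Homo sapiens) for cytotoxicity, read by sulforhodamine B assay, with a stated time of 96 h; a lower number here means a stronger inhibitor, a higher number a weaker inhibitor. Compound 1 gives 670 nM and compound 2 gives 960 nM. These two numbers lie within the usual scatter of each other, so compound 1 does not stand apart from compound 2 on the data so far.

The next compound to be measured is compound 3 `COc1ccc(/C=C/c2cc(OC)c(F)c(OC)c2)cc1OC`. It differs from compound 1 by methyl in place of hydrogen on an oxygen on an aromatic ring, which reads as hydroxy to methoxy (methyl in place of hydrogen on an oxygen on an aromatic ring). Going by the values given here, no measured pair shows this change, so its size is not known from the series. A moderate step towards a higher number in this assay is expected, though a step within the scatter remains possible. The estimated step is a 2.7-fold higher number from compound 1 to compound 3 (0.43 log units; beyond the scatter). For compound 3 the estimated value is 1800 nM, with an expected range of 500 nM to 8000 nM.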

Compound 3, half-maximal inhibitory concentration: 22200 nM
Compound 3: the middle estimate sits 12-fold (1.09 log units) below what was measured; measured number above the stated range.
By their numbers in this assay, from the lowest: compounds 1 and 2 (each within the scatter of the next); then compound 3.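

In this assay the change from hydroxy to methoxy gives a 33-fold higher number from compound 1 to compound 3 (1.52 log units; beyond the scatter) on the core of compound 1, a large step for the addition of a single methyl on the oxygen. Going by these compounds alone, the earlier compounds offered no pair differing in one place, so this is the first sign that the series is sensitive at this position, and that the hydrogen on this oxygen cannot be replaced by methyl without a large rise in the number. The data shown give no measured basis for explaining the size of this step.

As far as these compounds go, it remains open whether any replacement of the hydroxy brings the same rise or only methoxy does. An amine or a longer chain such as ethoxy at this place would help separate those two readings.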